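A few compounds are considered here, and "the series" means these few. Any claim that something is new, unique, unknown or untested is made for them only; others in the source may bear on it.

Measured compounds: compound 1 `C=C1CCCC(C)(C)C1CC[C@]1(C)CC[C@H]([C@@H](C)C(=O)OC)OO1` with 400 nM; compound 2 `C=C1CCC[C@H]2[C@](C)(CC[C@]3(C)CC[C@@H]([C@@H](C)C(=O)O)OO3)[C@@H](C)CC[C@]12C` with 950 nM; compound 3 `CC1=C(CC/C(C)=C/CC[C@@]2(C)CC[C@@H]([C@H](C)C(=O)O)OO2)C(C)(C)CCC1`.

In a functional assay on KM12 cells (Homo sapiens) for inhibition (a lower number here means a stronger inhibitor of growth, a higher number a weaker inhibitor of growth), compound 2 gives 950 nM, the higher of the two numbers reported, and compound 1 gives 400 nM, a gap described as beyond the usual scatter. For compound 3 this assay gives only a limit, > 100000 nM, and no number (the limit of > 100000 nM in this assay, at which 1 of the 3 values shown sits).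

Compound 4 `C=C1CCC[C@H]2[C@](C)(CC[C@]3(C)CC[C@H]([C@@H](C)C(=O)O)OO3)[C@@H](C)CC[C@]12C` is not yet measured. It differs from compound 2 as follows: the two compounds have the same atoms and bonds and differ only in configuration as drawn: 1 of 7 stereo elements differ; a stereocentre at a saturated ring carbon is drawn S in compound 2 and R in compound 4. Among the measured compounds shown here, no measured pair shows such a change alone, so its size cannot be read from these data; a modest weakening is expected in this assay, but not with confidence. For compound 4 the estimate is 2000 nM, between 500 nM and 10000 nM, a step of a 2.1-fold higher number from compound 2 to compound 4 (0.32 log units; beyond the scatter) that is expected rather than known.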

Compound 4, concentration for 50% growth inhibition: 940 nM
Compound 4: middle estimate off by 2.1-fold (0.33 log units), on the high side; low and high end bracket the measured number.
By their numbers in this assay, from the lowest: compound 1; then compounds 4 and 2 (each within the scatter of the next). At a limit, above all of these: compound 3.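

In this assay, among the compounds shown here, the only change is a stereocentre at a saturated ring carbon drawn S in compound 2 and R in compound 4, and it gives a 1.0-fold lower number from compound 2 to compound 4 (0.00 log units; within the scatter). For the compounds shown here, no earlier pair isolated a change of configuration alone. Here, the configuration at this ring carbon makes no difference beyond the scatter in this pair.

The compounds shown leave open whether the other stereo elements can be switched with as little consequence. They also leave open whether an amide in place of the carboxylic acid would keep this indifference to configuration.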